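Removing a ring methyl from a weak cytotoxic sulfonylguanidine

The compounds below may be only part of what the source reports. "The series", "measured", "known", "first", "only" and "open" are said of these compounds alone.

Measured compounds:
Compound 1 `Cc1cc(-c2ccccc2)n(/C(N)=N/S(=O)(=O)c2cc(C)c(Cl)cc2SCc2cccc3ccccc23)n1` — 170000 nM
Compound 2 `Cc1ccc(CSc2cc(Cl)c(C)cc2S(=O)(=O)/N=C(\N)n2nc(C)cc2-c2ccccc2)cc1` — 89000 nM
Compound 3 `Cc1cccc(CSc2cc(Cl)c(C)cc2S(=O)(=O)/N=C(\N)n2nc(C)cc2-c2ccccc2)c1` — 105000 nM

In a functional assay on MCF7 cells (Homo sapiens) for cytotoxicity, read by MTT assay, with a stated time of 72 h (a lower number here means a stronger inhibitor, a higher number a weaker inhibitor), compound 2 gives 89000 nM, the lowest of the three numbers, yet its separation from compound 3 is a 1.2-fold higher number from compound 2 to compound 3 (0.07 log units; within the scatter) and from compound 1 is a 1.9-fold lower number from compound 1 to compound 2 (0.28 log units; within the scatter), both within the scatter, so no ordering among the three can be claimed. The step from compound 1 to compound 3 is likewise small: a 1.6-fold lower number from compound 1 to compound 3 (0.21 log units; within the scatter).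

Compound 4 `Cc1ccc(CSc2cc(Cl)c(C)cc2S(=O)(=O)/N=C(\N)n2nccc2-c2ccccc2)cc1` has not been measured. It differs from compound 2 by hydrogen in place of methyl on an aromatic carbon, sitting on an aromatic carbon of a five-membered aromatic ring with 2 nitrogen, two ring bonds from the ring atom that bears a phenyl group. Among the measured compounds shown here, none of the measured steps touches this ring; all three concern the group on the saturated chain carbon bound to a sulfur, and all lay within the scatter. There is therefore no basis for expecting a change beyond the scatter, and the expected step is a 1.1-fold higher number from compound 2 to compound 4 (0.03 log units; within the scatter). Compound 4 is estimated at 95000 nM, within 40000 nM to 230000 nM.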

Compound 4, half-maximal inhibitory concentration: 21000 nM
Beside the measured number, compound 4's estimate is 4.5-fold (0.66 log units) above it, outside the stated range (below it).
By their numbers in this assay, from the lowest: compound 4; then compounds 2, 3 and 1 (each within the scatter of the next).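

In this assay, the methyl on an aromatic carbon of the five-membered aromatic ring with 2 nitrogen proves to matter: hydrogen in its place gives a 4.2-fold lower number from compound 2 to compound 4 (0.63 log units; beyond the scatter) and so stands apart from the changes on the saturated chain carbon bound to a sulfur, which all stayed within the scatter. This position, two ring bonds from the ring atom that bears a phenyl group, therefore responds to the loss of a single carbon, and the number moves toward stronger inhibition. Nothing measured here accounts for this step.

From the compounds shown here alone, whether the same change gives a similar step when naphthalen-1-yl or 3-methylphenyl sits on the chain carbon remains open. So does what an ethyl group, an amine or a carboxylic acid at this ring carbon would do to the number.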